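The source may hold more compounds than are shown below. What is called first, only, known or untested is meant among the compounds shown, and "the series" means these compounds.

Compound 1 `O=C(Nc1ccc2nc(NC(=O)C3CCC3)sc2c1)c1c(Cl)cccc1Cl`: in a functional assay on WI-38 VA13 cells (Homo sapiens) for cytotoxicity (a higher number here means that more compound is needed for the effect, a lower number that less compound is needed), compound 1 gives 0.013 ug/mL.
Compound 2 `CC(C)CC(=O)Nc1nc2ccc(NC(=O)c3c(Cl)cccc3Cl)cc2s1`: in this assay compound 2 gives 0.012 ug/mL.
Compound 3 `O=C(O)CCC(=O)Nc1nc2ccc(NC(=O)c3c(Cl)cccc3Cl)cc2s1`: in this assay compound 3 reaches only a limit of the assay, > 6.6 ug/mL.

The three compounds share one core and differ only in the group attached to the carbonyl carbon of the second amide. Between the cyclobutyl and isobutyl groups the step of a 1.1-fold lower number from compound 1 to compound 2 (0.03 log units; within the scatter) lies within the scatter. Among the compounds with values here, compound 3, which carries the 2-carboxyethyl group, is the single value among the three that stands at the limit (the limit of > 6.6 ug/mL in this assay, at which 1 of the 3 values shown sits); where its true number lies beyond that limit is not known. The steps of an at least 500-fold higher number from compound 1 to compound 3 (2.70 log units; beyond the scatter) and an at least 550-fold higher number from compound 2 to compound 3 (2.74 log units; beyond the scatter) are both large.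

Compound 4 `CC(C)(C)OC(=O)Nc1nc2ccc(NC(=O)c3c(Cl)cccc3Cl)cc2s1` differs from compound 3 by tert-butoxy in place of 2-carboxyethyl on a carbonyl carbon. The two steps leading into compound 3 are the ones that bear on this change: exchanging a neutral alkyl group for the 2-carboxyethyl group raised the number far beyond the scatter, and compound 4 removes that group again in favour of tert-butoxy. A large fall in this assay is therefore expected, roughly an at least 130-fold lower number from compound 3 to compound 4 (2.12 log units; beyond the scatter), because an at least 500-fold higher number from compound 1 to compound 3 (2.70 log units; beyond the scatter) and an at least 550-fold higher number from compound 2 to compound 3 (2.74 log units; beyond the scatter) were so large. Compound 4 is estimated at about 0.05 ug/mL, with a likely range from 0.01 ug/mL to 0.5 ug/mL.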

Compound 4, half-maximal effective concentration: 0.027 ug/mL
For compound 4 the middle estimate is 1.9-fold (0.27 log units) above the measured one; measured number inside the range.
By their numbers in this assay, from the lowest: compounds 2 and 1 (each within the scatter of the next); then compound 4. At a limit, above all of these: compound 3.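

In this assay, the carbonyl carbon on the amide-type nitrogen accepts tert-butoxy with a low number, and the change away from 2-carboxyethyl gives an at least 240-fold lower number from compound 3 to compound 4 (2.38 log units; beyond the scatter), so the high number of compound 3 does not follow from every change at this place. Compound 3 stands at a limit, which makes that step a minimum and not an exact size: the limit of > 6.6 ug/mL in this assay, at which 1 of the 4 values shown sits.

The comparison with the two carbon-linked groups adds a finer result, with a 2.3-fold higher number from compound 2 to compound 4 (0.35 log units; beyond the scatter) and a 2.1-fold higher number from compound 1 to compound 4 (0.32 log units; beyond the scatter), both modest but beyond the scatter, so an oxygen-linked tert-butoxy group keeps the number low, though not quite as low as isobutyl or cyclobutyl do.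

The compounds shown leave open whether the high number of compound 3 belongs to the carboxylic acid itself, which its methyl ester or a primary amide on the same chain could help to test. As far as these compounds go, how an amine at the end of that chain, or a shorter or longer chain carrying the carboxylic acid, would behave at this place also remains open.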